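Notes on the coumarin-free series: step from compound 3 to compound 4

This account rests on a few compounds, and the source may have more. Where it says the series, first, only, none or still open, it means among the compounds named here.

Measured so far:
compound 1 `O=c1oc(CO)cc2ccccc12` — >= 250 ug/mL in a functional assay on U-251 cells (Homo sapiens) for antiproliferative activity, read by sulforhodamine B assay, with a stated time of 48 h; a lower number here means a stronger inhibitor of growth, a higher number a weaker inhibitor of growth (a limit, not a number)
compound 2 `COc1ccc2cc(CCCO)oc(=O)c2c1` — 28.9 ug/mL
compound 3 `CCCCCOCCCc1cc2ccc(OC)cc2c(=O)o1` — 19.4 ug/mL

Compound 3 gives the lowest number of the two numbers in this assay; its nearest neighbour is compound 2, and the step of a 1.5-fold lower number from compound 2 to compound 3 (0.17 log units; within the scatter) lies within the scatter. Compound 1 sits at the limit of >= 250 ug/mL in this assay, at which 1 of the 3 values shown sits, and contributes no number.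

Compound 4 `COc1ccc2cc(CCCOCCCc3cccnc3)oc(=O)c2c1` differs from compound 3 by pyridin-3-yl in place of ethyl on a saturated chain carbon, three bonds along the chain from an oxygen on a saturated carbon. Among the compounds with values here, no measured step touches this position in this way; the only measured step, from compound 2 to compound 3, changed the same chain and stayed within the scatter. The expectation is therefore a step of modest size, a 1.3-fold lower number from compound 3 to compound 4 (0.11 log units; within the scatter), with no direction favoured beyond the scatter. Compound 4 is estimated at 15 ug/mL, between 6 ug/mL and 40 ug/mL.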

Compound 4, concentration for 50% growth inhibition: 26.3 ug/mL
For compound 4 the middle estimate is 1.8-fold (0.24 log units) below the measured one, and the stated range covers the measured number.
By their numbers in this assay, from the lowest: compounds 3, 4 and 2 (each within the scatter of the next). At a limit, above all of these: compound 1.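

In this assay the step to the ring-bearing chain end is a 1.4-fold higher number from compound 3 to compound 4 (0.13 log units; within the scatter), so pyridin-3-yl in place of ethyl at this saturated chain carbon brings no change beyond the scatter. The earlier step concerned only pentyl on the chain oxygen; this one shows that a six-membered aromatic ring with one nitrogen can stand on the same chain without leaving the scatter. Nothing in the data at hand bears on the reason for this result.

Phenyl in place of pyridin-3-yl would separate the effect of the ring from that of its nitrogen. Going by these compounds, whether an amine, a carboxylic acid or a longer chain at this place gives a step beyond the scatter remains open.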